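Does a Longer Hydroxyalkyl Chain Change the Read-Out?

A few compounds are considered here, and "the series" means these few. Any claim that something is new, unique, unknown or untested is made for them only; others in the source may bear on it.

In a functional assay on MCF7 cells (Homo sapiens) (on this read-out higher numbers stand for weaker inhibition and lower numbers for stronger inhibition), compound 1 (`COc1cc(NC(C)CCCNC(=O)NCCO)c2ncccc2c1`) gives 25000 nM. For the measured compounds named here, compound 2 (`COc1cc(NC(C)CCCNC(=O)NCCCO)c2ncccc2c1`) gives 31000 nM, so these two compounds lie within the scatter of each other, and compound 2 stands level with the only other number available. Compound 3 (`COc1cc(NC(C)CCCNC(=O)NCCCCCO)c2ncccc2c1`) alters the same chain end, which goes from 3-hydroxypropyl to 5-hydroxypentyl: 2-hydroxyethyl in place of hydroxy on a saturated chain carbon, three bonds along the chain from an amide-type nitrogen. Going by the values given here, one measured step bears on this change, and it also extends that chain: a 1.2-fold higher number from compound 1 to compound 2 (0.09 log units; within the scatter). That step is small, but a single pair is thin evidence, and the new extension is larger. No shift beyond the scatter is therefore expected in this assay, and no direction can be favoured. The estimated step is a 1.0-fold lower number from compound 2 to compound 3 (0.01 log units; within the scatter). Compound 3 is expected at 30000 nM, with an estimated range of 14000 nM to 60000 nM.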

Compound 3, half-maximal inhibitory concentration: 44000 nM
Compound 3: the middle estimate sits 1.5-fold (0.17 log units) below what was measured; the range from low to high includes it.
By their numbers in this assay, from the lowest: compounds 1, 2 and 3 (each within the scatter of the next).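

For the compounds shown here, with the 5-hydroxypentyl end, the test of chain length at this position becomes wider than the single small step seen before. In this assay, the further extension gives a 1.4-fold higher number from compound 2 to compound 3 (0.15 log units; within the scatter) and the full span of the series gives a 1.8-fold higher number from compound 1 to compound 3 (0.25 log units; within the scatter), so even the largest change shown here, 3-hydroxypropyl in place of hydroxy, stays inside the scatter and these three hydroxyalkyl ends cannot be told apart on this read-out. No independent measurement is available that could explain these numbers.

Going by these compounds, it remains open whether a still longer chain, such as a 7-hydroxyheptyl end, would move the number beyond the scatter. An amine or a carboxylic acid in place of the hydroxy at the chain end is also an open case, since every end shown here finishes in a hydroxy group.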